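The source may hold more compounds than are shown below. What is called first, only, known or untested is meant among the compounds shown, and "the series" means these compounds.

Of the compounds shown here, two have been measured so far. Compound 1 `CCCCCCCCCCCC[S+]([O-])CC(=O)C(F)(F)F` gives 12 nM in an assay for inhibition of liver carboxylesterase (Sus scrofa), with a stated time of 5 min; a lower number here means a stronger inhibitor, a higher number a weaker inhibitor. Compound 2 `CCCCCCCCCCS(=O)(=O)CC(=O)C(F)(F)F` gives 63 nM in this assay, the higher of the two numbers, and its gap to compound 1 lies beyond the usual scatter. Compound 3 `CCCCCCCCCCCCS(=O)(=O)CC(=O)C(F)(F)F` awaits measurement; it differs from compound 2 by ethyl in place of hydrogen on a saturated chain carbon, ten or more bonds along the chain from a sulfonyl sulfur and so carries the same chain length as compound 1. A moderate step toward a lower number is expected from compound 2 to compound 3, a 2.1-fold lower number from compound 2 to compound 3 (0.32 log units; beyond the scatter), because compound 1 with that chain reaches 12 nM. Compound 3 is therefore estimated at 30 nM, within 12 nM to 80 nM.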

Compound 3, half-maximal inhibitory concentration: 37 nM
Compound 3: middle estimate off by 1.2-fold (0.09 log units), on the low side, within the range that was stated.
By their numbers in this assay, from the lowest: compound 1; then compounds 3 and 2 (each within the scatter of the next).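

In this assay, ethyl in place of hydrogen on a saturated chain carbon, ten or more bonds along the chain from a sulfonyl sulfur, gives a 1.7-fold lower number from compound 2 to compound 3 (0.23 log units; within the scatter) and so stays within the scatter. At this place, then, the change leaves compound 2 and compound 3 indistinguishable in this assay. No supporting measurement bears on this result. As far as these compounds go, it remains open whether a longer chain, or a carboxylic acid or an amine at the chain end, would give a step beyond the scatter.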